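Swapping the Thiophene Ring for a Furan in Compound 1

This account rests on a few compounds, and the source may have more. Where it says the series, first, only, none or still open, it means among the compounds named here.

Compound 1 `CCN(Cc1cccs1)C(=O)COc1ccc(C)cc1` gives the lowest number of the three measured compounds in an assay on HEK293 cells for agonist activity at transient receptor potential cation channel subfamily M member 8 (Homo sapiens), read by fluorescence and calcium flux, with a stated time of 15 min (on this read-out higher numbers stand for an effect only at larger amounts of compound and lower numbers for an effect already at smaller amounts), at 8 nM. Compound 2 `Cc1ccc(OCC(=O)N(Cc2cccs2)c2cccnc2)cc1` gives 198 nM, and compound 3 `Cc1ccc(OCC(=O)N(Cc2cccs2)CC(C)C)cc1` gives 900 nM. Compound 4 `CCN(Cc1ccoc1)C(=O)COc1ccc(C)cc1` differs from compound 1 by furan-3-yl in place of thiophen-2-yl on a saturated chain carbon bound to an amide-type nitrogen. Among the measured compounds shown here, none of the measured steps touches this ring: a 25-fold higher number from compound 1 to compound 2 (1.39 log units; beyond the scatter) and a 110-fold higher number from compound 1 to compound 3 (2.05 log units; beyond the scatter) both alter the other group on the nitrogen, and a 4.5-fold higher number from compound 2 to compound 3 (0.66 log units; beyond the scatter) likewise. The data therefore offer no direct guide. The change keeps one five-membered aromatic ring with 1 hetero atom. A modest step is expected, most likely toward a higher number, a 2.5-fold higher number from compound 1 to compound 4 (0.40 log units; beyond the scatter). Compound 4 is estimated at 20 nM, within 5 nM to 80 nM.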

Compound 4, half-maximal effective concentration: 136 nM
For compound 4 the middle estimate is 6.8-fold (0.83 log units) below the measured one, and the stated range ends below it.
By their numbers in this assay, from the lowest: compound 1; then compounds 4 and 2 (each within the scatter of the next); then compound 3.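

In this assay the ring on the saturated chain carbon clearly matters: exchanging one five-membered aromatic ring for another with the same counts of heavy atoms and hydrogen-bond acceptors still gives a 17-fold higher number from compound 1 to compound 4 (1.23 log units; beyond the scatter) as a large step. Among the compounds shown here, this place, untouched by the earlier compounds, is therefore sensitive too. No measurement given here explains the step. Sulfur gives way to oxygen and the ring's point of attachment changes at once, and the compounds shown do not separate the two. Going by these compounds, how a phenyl ring would fare in this place also stays open.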